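Ester chain variation on the shared core

The source may report more compounds than this note shows. Statements on the series, on what has been measured and on what is new or still open speak of the compounds shown alone.

Measured so far:
compound 1 `CCOC(=O)C1=C(C)NC(/C=C/c2ccc([N+](=O)[O-])cc2)=C(C(=O)OCC)C1c1cccc([N+](=O)[O-])c1` — 2060 nM
compound 2 `COC(=O)C1=C(C)NC(C)=C(C(=O)OCCCl)C1c1cccc([N+](=O)[O-])c1` — 22 nM

In a functional assay on HEK293 cells for antagonist activity at Voltage-dependent L-type calcium channel subunit alpha-1D (Rattus norvegicus), read by FLIPR (a lower number here means a stronger inhibitor, a higher number a weaker inhibitor), compound 2 gives 22 nM and compound 1 gives 2060 nM; compound 2 has the lowest number of the two, and the gap to compound 1 lies beyond the scatter. Compound 3 `COC(=O)C1=C(C)NC(C)=C(C(=O)OCc2ccccc2)C1c1cccc([N+](=O)[O-])c1` is not yet measured. It differs from compound 2 in one place: phenyl in place of chloromethyl on a saturated chain carbon bound to an oxygen next to a carbonyl group. For the measured compounds named here, no comparable step between measured compounds is available, so the expectation rests on compound 2 alone. The expected step from compound 2 to compound 3 is a 1.6-fold higher number from compound 2 to compound 3 (0.20 log units; within the scatter), i.e. not beyond the scatter. Compound 3 is estimated at 35 nM, range 9 nM to 140 nM.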

Compound 3, half-maximal inhibitory concentration: 15 nM
Estimate against measurement, compound 3: 2.3-fold (0.37 log units) above; the range from low to high includes it.
By their numbers in this assay, from the lowest: compounds 3 and 2 (each within the scatter of the next); then compound 1.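

Phenyl in place of chloromethyl on a saturated chain carbon bound to an oxygen next to a carbonyl group gives a 1.5-fold lower number from compound 2 to compound 3 (0.17 log units; within the scatter) in this assay and so leaves the reading unchanged. At this position, 2-chloroethyl and benzyl cannot be told apart, although the entering group brings one six-membered aromatic ring and more heavy atoms. No measurement at hand bears on why the two read alike. Going by these compounds, whether an amine, a carboxylic acid or a longer chain would fit here as well remains open.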